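The source may report more compounds than this note shows. Statements on the series, on what has been measured and on what is new or still open speak of the compounds shown alone.

Compound 2 `COc1cccc(NC(=O)NC2CC(C)(C)Oc3ccc(F)cc32)c1` belongs to a small set built on a shared core and tested in a functional assay (aorta) with Rattus norvegicus as the target; a higher number here means that more compound is needed for the effect, a lower number that less compound is needed. In this assay compound 2 gives > 10000 nM, which is a limit of the assay rather than a number. Within the data shown here, compound 1 `COc1ccccc1NC(=O)NC1CC(C)(C)Oc2ccc(F)cc21` is the only other measured member of the set. In this assay compound 1 gives > 10000 nM, again a limit. Among the measured compounds shown here, the one step measured so far, a step that the two limits leave unreadable from compound 1 to compound 2, is therefore of unknown size. Compound 3 `Cc1ccccc1NC(=O)NC1CC(C)(C)Oc2ccc(F)cc21` has not yet been measured; it differs from compound 2 by 2-methylphenyl in place of 3-methoxyphenyl on an amide-type nitrogen. For the measured compounds named here, no readable step bears on this change, and the only evidence is the limit of > 10000 nM in this assay, at which 2 of the 2 values shown sit. The size of the step in this assay therefore cannot be drawn from the data, and the likeliest outcome is another limit. Compound 3 is estimated at 15000 nM, with a range from 3000 nM to 100000 nM. That estimate means a step that the limit leaves unreadable from compound 2 to compound 3, expected to stay unresolved rather than to show a real change.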

Compound 3, half-maximal effective concentration: > 30000 nM
Compound 3 gave a limit, no number; the forecaster's own chance of this, stated with the estimate: 75%; at least 2.0-fold (0.30 log units) between middle value and limit.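

Compound 3 gives only a limit, not a number, as do compound 1 and compound 2, so no step among these three compounds can be read. The compounds shown leave open how much of each is needed for the effect, and whether 2-methylphenyl, 2-methoxyphenyl or 3-methoxyphenyl on the amide-type nitrogen makes any difference.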